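Shifting a Methoxy Group on the Sulfonyl Aryl Ring

The compounds below may be only part of what the source reports. "The series", "measured", "known", "first", "only" and "open" are said of these compounds alone.

Measured so far in a functional assay on SMMC-7721 cells (Homo sapiens) for antiproliferative activity, read by MTT assay, with a stated time of 72 h; on this read-out higher numbers stand for weaker inhibition and lower numbers for stronger inhibition:
- compound 1 `CN(c1ccc2[nH]c(-c3n[nH]c4ccccc34)cc2n1)S(=O)(=O)c1ccc(Cl)cc1`: 12700 nM
- compound 2 `COc1ccc(S(=O)(=O)N(C)c2ccc3[nH]c(-c4n[nH]c5ccccc45)cc3n2)cc1OC`: 26600 nM

Among the compounds with values here, compound 2 holds the higher of the two numbers; its only neighbour is compound 1, and the single measured step, a 2.1-fold higher number from compound 1 to compound 2 (0.32 log units; beyond the scatter), separates them beyond the scatter. Compound 3 `COc1ccc(S(=O)(=O)N(C)c2ccc3[nH]c(-c4n[nH]c5ccccc45)cc3n2)c(OC)c1` is built from the same atoms as compound 2, joined differently: 2,4-dimethoxyphenyl in place of 3,4-dimethoxyphenyl on a sulfonyl sulfur. Within the data shown here, no measured step exchanges one dimethoxyphenyl for another, so nothing bears directly on this change. Among the measured compounds shown here, the one step that exists, a 2.1-fold higher number from compound 1 to compound 2 (0.32 log units; beyond the scatter), swaps a chlorophenyl for a dimethoxyphenyl and is modest even then; moving one methoxy group within the same ring is a smaller alteration than that. On this basis compound 3 is expected to stay close to compound 2, with the estimated step of a 1.1-fold lower number from compound 2 to compound 3 (0.03 log units; within the scatter) lying within the scatter in this assay. The estimate for compound 3 in this assay is therefore 25000 nM, with a range from 9000 nM to 70000 nM.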

Compound 3, half-maximal inhibitory concentration: 10800 nM
Estimate against measurement, compound 3: 2.3-fold (0.36 log units) above; low and high end bracket the measured number.
By their numbers in this assay, from the lowest: compounds 3 and 1 (each within the scatter of the next); then compound 2.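

In this assay, the way the two methoxy groups are arranged on the ring carried by the sulfonyl sulfur proves to count: with the atoms unchanged, 2,4-dimethoxyphenyl in place of 3,4-dimethoxyphenyl gives (a 2.5-fold lower number from compound 2 to compound 3 (0.39 log units; beyond the scatter)), a modest step, as was the earlier exchange of the 4-chlorophenyl for the 3,4-dimethoxyphenyl. The higher number of compound 2 therefore does not follow from having a dimethoxyphenyl at this place, since 2,4-dimethoxyphenyl in place of 4-chlorophenyl gives (a 1.2-fold lower number from compound 1 to compound 3 (0.07 log units; within the scatter)), which leaves compound 1 and compound 3 level within the scatter, and among these three compounds only the 3,4-dimethoxyphenyl stands apart. Nothing available accounts for this difference between the two arrangements.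

The three compounds leave open whether either methoxy group alone produces the shift, as a phenyl ring with a single methoxy group could show. They also leave open how this place on the sulfonyl sulfur would respond to quite different groups, such as an amine or a carboxylic acid on the ring, and whether any such group would move the number beyond the level of compound 1 and compound 3.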